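The source may hold more compounds than are shown below. What is called first, only, known or untested is meant among the compounds shown, and "the series" means these compounds.

Measured in a functional assay on P388 cells (Mus musculus) for cytotoxicity; a higher number here means a weaker inhibitor, a lower number a stronger inhibitor:
compound 1 `CCCN1C(=O)[C@@H](C)NC(=O)[C@@H]2Cc3ccc(OC)c(c3)Oc3ccc(cc3)C[C@@H](C(=O)N2C)N(C)C(=O)[C@H](C)NC(=O)[C@H](Cc2ccc(OC)cc2)N(C)C(=O)[C@@H]1C`: 3.98 nM
compound 2 `C/C=C/CN1C(=O)[C@@H](C)NC(=O)[C@@H]2Cc3ccc(OC)c(c3)Oc3ccc(cc3)C[C@@H](C(=O)N2C)N(C)C(=O)[C@H](C)NC(=O)[C@H](Cc2ccc(OC)cc2)N(C)C(=O)[C@@H]1C`: 9.12 nM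
compound 3 `CC/C=C/CN1C(=O)[C@@H](C)NC(=O)[C@@H]2Cc3ccc(OC)c(c3)Oc3ccc(cc3)C[C@@H](C(=O)N2C)N(C)C(=O)[C@H](C)NC(=O)[C@H](Cc2ccc(OC)cc2)N(C)C(=O)[C@@H]1C`: 12 nM

Two steps fix the standing of the last of these: a 1.3-fold higher number from compound 2 to compound 3 (0.12 log units; within the scatter), and a 3.0-fold higher number from compound 1 to compound 3 (0.48 log units; beyond the scatter). Compound 4 `C=C(C)CN1C(=O)[C@@H](C)NC(=O)[C@@H]2Cc3ccc(OC)c(c3)Oc3ccc(cc3)C[C@@H](C(=O)N2C)N(C)C(=O)[C@H](C)NC(=O)[C@H](Cc2ccc(OC)cc2)N(C)C(=O)[C@@H]1C` has not yet been measured. Compared with compound 3, it carries 1-methylethenyl in place of but-1-en-1-yl on a saturated chain carbon bound to an amide-type nitrogen in a ring. Among the compounds with values here, no measured step introduces 1-methylethenyl. The nearest guides are the modest 2.3-fold higher number from compound 1 to compound 2 (0.36 log units; beyond the scatter) and the step between the two unsaturated chains, which stayed within the scatter. A step within the scatter is therefore expected in this assay, with only a slight lean toward a lower number. The expected step is a 1.5-fold lower number from compound 3 to compound 4 (0.18 log units; within the scatter). The estimate for compound 4 is 8 nM, with an expected range of 3.5 nM to 18 nM.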

Compound 4, half-maximal inhibitory concentration: 11 nM
Compound 4: middle estimate off by 1.4-fold (0.14 log units), on the low side; measured number inside the range.
By their numbers in this assay, from the lowest: compound 1; then compounds 2, 4 and 3 (each within the scatter of the next).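

At this position in this assay, a branched unsaturated chain stands level with the straight ones: 1-methylethenyl in place of but-1-en-1-yl gives a 1.1-fold lower number from compound 3 to compound 4 (0.04 log units; within the scatter), and in place of prop-1-en-1-yl it gives a 1.2-fold higher number from compound 2 to compound 4 (0.08 log units; within the scatter). Against ethyl, the same group gives a 2.8-fold higher number from compound 1 to compound 4 (0.44 log units; beyond the scatter), so compounds 2, 3 and 4 all stand apart from compound 1, whatever the shape of their unsaturated chain. No evidence is available that would explain these results. From the compounds shown here alone, it remains open whether the double bond itself accounts for the gap from compound 1. Going by these compounds, how a saturated branched chain such as 2-methylpropyl, or a chain ending in an amine, would stand here is also open.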